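A few compounds are considered here, and "the series" means these few. Any claim that something is new, unique, unknown or untested is made for them only; others in the source may bear on it.

Of the compounds shown here, three sharing one core have been measured for how tightly they bind, and all three sit close together. In an assay for binding affinity to 5-hydroxytryptamine receptor 1F (Homo sapiens), read by radioligand binding (on this read-out lower numbers stand for stronger inhibition and higher numbers for weaker inhibition), compound 1 `CN1CCC(c2c[nH]c3cnc(NC(=O)c4ccc(F)cc4)cc23)CC1` gives 13 nM, compound 2 `CCCCCC(=O)Nc1ccc2[nH]cc(C3CCN(C)CC3)c2n1` gives 13 nM, and compound 3 `CN1CCC(c2c[nH]c3ccc(NC(=O)C4CCCCC4)nc23)CC1` gives 20 nM. Compound 3 therefore holds the highest of the three numbers, yet its distance to compound 1 and to compound 2 lies within the scatter of the method, so no real difference among them can be claimed. Among the measured compounds shown here, the only single-point step among them, a 1.5-fold higher number from compound 2 to compound 3 (0.19 log units; within the scatter), swaps one saturated carbon group for another on the carbonyl carbon and changes nothing beyond the scatter.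

Compound 4 `CN1CCC(c2c[nH]c3ccc(NC(=O)c4ccc(C#N)cc4)nc23)CC1` differs from compound 3 in the same place: 4-cyanophenyl in place of cyclohexyl on a carbonyl carbon. For the measured compounds named here, the one comparable step, a 1.5-fold higher number from compound 2 to compound 3 (0.19 log units; within the scatter), suggests that this position tolerates exchange of the group on the carbonyl carbon without a large shift. Compound 1, which also carries a six-membered aromatic ring on its carbonyl carbon, gives 13 nM, a number in the same band. For compound 4 the expected step is a 1.3-fold lower number from compound 3 to compound 4 (0.12 log units; within the scatter), a movement that stays within the scatter. Compound 4 is thus estimated at 15 nM, with a range of 6 nM to 40 nM.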

Compound 4, inhibition constant: 7.2 nM
Compound 4: middle estimate off by 2.1-fold (0.32 log units), on the high side; low and high end bracket the measured number.
By their numbers in this assay, from the lowest: compounds 4, 1, 2 and 3 (each within the scatter of the next, the first and the last beyond it).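

In this assay, among the compounds shown here, placing 4-cyanophenyl instead of cyclohexyl on the carbonyl carbon gives a 2.8-fold lower number from compound 3 to compound 4 (0.44 log units; beyond the scatter) and is the first step at this position to clear the scatter, though only modestly. This shows that the number can respond to the group held on the carbonyl carbon, which the earlier step between pentyl and cyclohexyl could not show, but the result depends on the comparison: placing 4-cyanophenyl instead of pentyl gives a 1.8-fold lower number from compound 2 to compound 4 (0.26 log units; within the scatter) and stays within the scatter. Nothing shown here offers a measured explanation for the step from cyclohexyl to 4-cyanophenyl.

The compounds shown leave open whether the aromatic ring or the nitrile on it accounts for the step, and a plain phenyl group on the carbonyl carbon would help separate the two. A carboxylic acid or an amine in place of the nitrile would then test whether this part of the group can change freely, while a longer chain in place of pentyl would show how far the saturated side of the series extends.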